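The compounds below may be only part of what the source reports. "The series", "measured", "known", "first", "only" and "open" are said of these compounds alone.

Measured in a functional assay on NCI-H1975 cells (Homo sapiens) for antiproliferative activity, read by MTT assay, with a stated time of 72 h; a higher number here means a weaker inhibitor, a lower number a stronger inhibitor:
- compound 1 `C=CC(=O)Nc1cc2c(Nc3ccc(F)c(Cl)c3)ncnc2cc1OCc1cn(CCC(=O)NO)nn1`: 4450 nM
- compound 2 `C=CC(=O)Nc1cc2c(Nc3ccc(F)c(Cl)c3)ncnc2cc1OCc1cn(CCCC(=O)NO)nn1`: 1820 nM
- compound 3 `C=CC(=O)Nc1cc2c(Nc3ccc(OCc4cccc(F)c4)c(Cl)c3)ncnc2cc1OCc1cn(CCC(=O)NO)nn1`: 21000 nM

Compound 1 stands second highest of these three numbers, with compound 2 lower and compound 3 higher. Compound 4 `C=CC(=O)Nc1cc2c(Nc3cccc(Cl)c3F)ncnc2cc1OCc1cn(CCC(=O)NO)nn1` has the same atoms as compound 1, joined differently: 3-chloro-2-fluorophenyl in place of 3-chloro-4-fluorophenyl on a nitrogen on an aromatic ring. The fluorine and chlorine stay on the phenyl group, but the fluorine sits elsewhere on it.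

Two measured steps offer a guide. The closer one is a 4.7-fold higher number from compound 1 to compound 3 (0.67 log units; beyond the scatter), which also alters this phenyl group, although there a (3-fluorobenzyl)oxy replaces the fluoro and new atoms enter. The other is a 2.4-fold lower number from compound 1 to compound 2 (0.39 log units; beyond the scatter), which alters the hydroxycarbamoyl chain instead and so says little here. On these data alone, neither shows what moving the fluorine does, and the direction stays open. As this change adds no atoms, a step smaller than the modest one seen on that phenyl group seems likely.

The expected step is a 1.1-fold lower number from compound 1 to compound 4 (0.05 log units; within the scatter), which would not clearly exceed the scatter. Compound 4 is estimated at 4000 nM, with an expected range of 1500 nM to 11000 nM.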

Compound 4, half-maximal inhibitory concentration: 6610 nM
Beside the measured number, compound 4's estimate is 1.7-fold (0.22 log units) below it; measured number inside the range.
By their numbers in this assay, from the lowest: compound 2; then compounds 1 and 4 (each within the scatter of the next); then compound 3.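

In this assay the swap of 3-chloro-4-fluorophenyl for 3-chloro-2-fluorophenyl on the nitrogen gives a 1.5-fold higher number from compound 1 to compound 4 (0.17 log units; within the scatter) and so produces no clear change. Compound 3 had shown only that adding a (3-fluorobenzyl)oxy group to this phenyl group moves the number beyond the scatter, whereas compound 4 shows that rearranging the same atoms on the ring need not do so, at least for this one move of the fluorine. Nothing available here explains why the two arrangements read so alike.

Still open, on these data alone, is whether the longer chain of compound 2 would give a similar step when paired with 3-chloro-2-fluorophenyl. Also open, as far as these compounds go, is how this phenyl group would fare with a methoxy group in place of the fluorine, or with a plain phenyl group carrying neither halogen.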